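The source may report more compounds than this note shows. Statements on the series, on what has been measured and on what is new or still open speak of the compounds shown alone.

Working notes on the series. Compound 1 `O=C(CCCCCCc1nc2ccccc2[nH]1)NO` gives 2700 nM in a functional assay on SK-OV-3 cells (Homo sapiens) for cytotoxicity (a lower number here means a stronger inhibitor, a higher number a weaker inhibitor), and stands second highest of the three numbers measured. Compound 2 `O=C(CCCCCCc1nc2ccc(Cl)cc2[nH]1)NO` gives 320 nM in this assay, and compound 3 `COc1ccc(-c2ccc3nc(CCCCCCC(=O)NO)[nH]c3c2)cc1` gives 3100 nM. The step of an 8.4-fold lower number from compound 1 to compound 2 (0.93 log units; beyond the scatter) and the step of a 9.7-fold higher number from compound 2 to compound 3 (0.99 log units; beyond the scatter) lie beyond the scatter, while a 1.1-fold higher number from compound 1 to compound 3 (0.06 log units; within the scatter) lies within it. Compound 4 `O=C(CCCCCCc1nc2ccccc2n1C1CC1)NO` differs from compound 1 by cyclopropyl in place of hydrogen on an aromatic nitrogen. Going by the values given here, every measured step concerns a group on an aromatic carbon; none touches the aromatic nitrogen, so no measured step bears directly on this change, and the direction cannot be read from the series. A step not beyond the scatter is expected, and compound 4 is estimated at 3500 nM, with a range from 1000 nM to 12000 nM. The expected step is a 1.3-fold higher number from compound 1 to compound 4 (0.11 log units; within the scatter).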

Compound 4, half-maximal inhibitory concentration: 9500 nM
Estimate against measurement, compound 4: 2.7-fold (0.43 log units) below; the measured number falls inside the stated range.
By their numbers in this assay, from the lowest: compound 2; then compounds 1 and 3 (each within the scatter of the next); then compound 4.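

In this assay cyclopropyl in place of hydrogen on an aromatic nitrogen gives a 3.5-fold higher number from compound 1 to compound 4 (0.55 log units; beyond the scatter) and so moves toward a weaker inhibitor. Going by these compounds alone, this is the first reading at this position, where the earlier steps, all on an aromatic carbon, said nothing. No measurement at hand accounts for the step.

From the compounds shown here alone, whether a methyl group or an aminoethyl chain on the same nitrogen gives a step in the same direction stays open. Also open, going by these compounds, is whether chloro on an aromatic carbon, as in compound 2, keeps its step with cyclopropyl on this nitrogen.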